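Adding a Methyl Group to the Core of Compound 1

This account rests on a few compounds, and the source may have more. Where it says the series, first, only, none or still open, it means among the compounds named here.

Compound 1 `O=C(CCN1CCCC1)c1cc2ccc(O)cc2oc1=O`: > 200000 nM
Compound 2 `O=C(CCN1CCCCC1)c1cc2ccc(O)cc2oc1=O`: > 200000 nM
Compound 3 `COc1ccc2cc(C(=O)CCN3CCCC3)c(=O)oc2c1`: 18100 nM

In an assay on cells for inhibition of Amine oxidase [flavin-containing] B (Homo sapiens), read by fluorescence, spectrophotometry and Amplex Red, with stated times of 60 min and 30 min (a lower number here means a stronger inhibitor, a higher number a weaker inhibitor), compound 1 gives > 200000 nM, which is a limit of the assay rather than a number. Compound 2 also gives > 200000 nM, again a limit. The step that the two limits leave unreadable from compound 1 to compound 2 can therefore not be read. Compound 3 gives 18100 nM, and the step of an at least 11-fold lower number from compound 1 to compound 3 (1.04 log units; beyond the scatter) is a large one, though it changes an oxygen rather than a ring carbon. Compound 4 `Cc1cc(O)cc2oc(=O)c(C(=O)CCN3CCCC3)cc12` differs from compound 1 by methyl in place of hydrogen on an aromatic carbon. Among the compounds with values here, no measured step alters a ring carbon, so none bears on this change directly, and the limit of > 200000 nM in this assay, at which 2 of the 3 values shown sit, means only a clearly lower number for compound 4 could be read at all. Compound 4 is therefore expected to give 200000 nM in this assay, between 40000 nM and 1000000 nM. The expected step is a number no higher from compound 1 to compound 4 (the limit leaves the size open), most likely not beyond the scatter.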

Compound 4, half-maximal inhibitory concentration: 43700 nM
For compound 4 the middle estimate is 4.6-fold (0.66 log units) above the measured one; low and high end bracket the measured number.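

The step of an at least 4.5-fold lower number from compound 1 to compound 4 (0.66 log units; beyond the scatter) shows that a methyl on an aromatic carbon of the core, and not only on the oxygen, can bring a readable number in this assay. Compound 4 keeps the hydroxy group of compound 1, so a readable number is possible with that group still in place. The value of compound 1 is a limit, so the true size of this step stays open: the limit of > 200000 nM in this assay, at which 2 of the 4 values shown sit.

From the compounds shown here alone, whether an ethyl group or a chlorine atom on this same carbon would lower the number further remains open. So does the outcome of placing methyl on both this carbon and the oxygen.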